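The compounds below may be only part of what the source reports. "The series", "measured", "known", "first", "only" and "open" are said of these compounds alone.

Compound 2 `COc1cccc(CCOc2ccc(-c3c(C)nc(C)c([C@H](OC(C)(C)C)C(=O)O)c3N3CCC(C)(C)CC3)cc2)c1` carries a 3-methoxyphenyl group on a saturated chain carbon, two bonds along the chain from an oxygen on an aromatic ring. In an ADME assay on microsomes from liver (Homo sapiens) for metabolic stability, read by LC-MS, tested at 0.5 uM (on this read-out higher numbers stand for a longer-lived compound and lower numbers for a shorter-lived compound), compound 2 reaches the limit of > 2 h, so only a limit and no number is known for it. The closely related compound 1 `COc1ccc(CCOc2ccc(-c3c(C)nc(C)c([C@H](OC(C)(C)C)C(=O)O)c3N3CCC(C)(C)CC3)cc2)cc1` has a 4-methoxyphenyl in that place. In this assay compound 1 likewise sits at the limit of > 2 h. The step that the two limits leave unreadable from compound 1 to compound 2 therefore cannot be read, because the limit of > 2 h in this assay, at which 2 of the 2 values shown sit, holds both values. Compound 3 `Cc1cc(CCOc2ccc(-c3c(C)nc(C)c([C@H](OC(C)(C)C)C(=O)O)c3N3CCC(C)(C)CC3)cc2)ccc1F` brings the change (4-fluoro-3-methylphenyl in place of 3-methoxyphenyl on a saturated chain carbon, two bonds along the chain from an oxygen on an aromatic ring). No measured step tells how such a change acts, and the one step shown stays unreadable. For compound 3 the expected half-life is 3 h, within an estimated range of 1.2 h to 8 h. That estimate means an expected step that the limit leaves unreadable from compound 2 to compound 3.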

Compound 3, half-life: > 2 h
Compound 3: no number, only a limit; the forecaster's own chance of this, stated with the estimate: 60%; the middle value is on the limit's open side.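

Compound 3 also gives a limit and not a number, so the steps from compound 1 and from compound 2 to compound 3 cannot be read: the limit of > 2 h in this assay, at which 3 of the 3 values shown sit. The compounds shown leave open whether the half-lives of compound 1, compound 2 and compound 3 differ at all in this assay.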